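The source may hold more compounds than are shown below. What is called first, only, known or untested is meant among the compounds shown, and "the series" means these compounds.

Measured so far in a functional assay on HL-60 cells (Homo sapiens) for cytotoxicity, read by MTT assay, with a stated time of 48 h; on this read-out higher numbers stand for weaker inhibition and lower numbers for stronger inhibition:
- compound 1 `O=C(Nc1cc(C(F)(F)F)ccc1N1CCCC1)c1cccnc1Cl`: "not active" (no number reported)
- compound 2 `O=C(Nc1cc(C(F)(F)F)ccc1Nc1ccc(Br)cc1)c1ccncc1`: "not active" (no number reported)
- compound 3 `O=C(Nc1cc(C(F)(F)F)ccc1NC1CCCCC1)c1ccccc1`: 34900 nM

Compound 2 stands without a single number in this assay; compound 1 likewise lacks one, so only compound 3 carries a value, and that value is weak. Compound 4 `CCN(CC)c1ccc(C(F)(F)F)cc1NC(=O)c1ccncc1` differs from compound 2 by diethylamino in place of (4-bromophenyl)amino on an aromatic carbon. Going by the values given here, no step between measured compounds is available to size such a change. Given that compound 2 returned no number and compound 3 sits at a weak level, no shift beyond the usual scatter is anticipated in either direction, and an outcome without a number stays quite possible. Compound 4 is expected to give about 40000 nM in this assay, within a range of 10000 nM to 150000 nM.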

Compound 4, half-maximal inhibitory concentration: 89700 nM
Compound 4: the middle estimate sits 2.2-fold (0.35 log units) below what was measured; the measured number falls inside the stated range.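

In this assay, going by these compounds alone, compound 2 carries no number, so no step to compound 4 can be read. No supporting measurement bears on this result. The compounds shown leave open how far diethylamino in place of (4-bromophenyl)amino moves the value, if at all.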